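This account rests on a few compounds, and the source may have more. Where it says the series, first, only, none or still open, it means among the compounds named here.

Compound 1 `COc1cccc(OC)c1C(=O)Nc1c[nH]nc1C(=O)NN1CCOCC1` gives in an ADME assay on MRC5 cells (Homo sapiens) for inhibition, with a stated time of 72 h (a lower number here means that less compound is needed, a higher number that more compound is needed for the effect), only a limit, > 50000 nM, and no number. Among the three measured compounds it sits at the limit of > 50000 nM in this assay, at which 2 of the 3 values shown sit. Compound 3 `COc1cc(OC)c(C(=O)Nc2c[nH]nc2C(=O)N[C@H]2CC[C@H](OC)CC2)c(OC)c1` likewise returns only a limit, > 50000 nM. Compound 2 `CO[C@H]1CC[C@H](NC(=O)c2n[nH]cc2NC(=O)c2ccccc2)CC1` gives a measured number in this assay, 800 nM. Compound 4 `COCCNC(=O)c1n[nH]cc1NC(=O)c1c(OC)cccc1OC` has not been measured in this assay; it differs from compound 1 by 2-methoxyethyl in place of morpholin-4-yl on an amide-type nitrogen. Since the rest of compound 1 stays unchanged, the step from compound 1 to compound 4 is expected to be none beyond the scatter, a number no higher from compound 1 to compound 4 (the limit leaves the size open). Compound 4 is therefore estimated at 50000 nM, within a range of 10000 nM to 200000 nM, most likely reported again only as a limit.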

Compound 4, half-maximal effective concentration: > 50000 nM
Compound 4 gave a limit, no number; the forecaster's own chance of this, stated with the estimate: 70%; the middle value lies on the limit itself.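

Compound 1 and compound 4 both return only a limit in this assay, and the step between them cannot be read. The compounds shown leave open whether 2-methoxyethyl in place of morpholin-4-yl changes the value at all.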